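The source may hold more compounds than are shown below. What is called first, only, known or untested is meant among the compounds shown, and "the series" means these compounds.

Of the compounds shown here, three built on one shared core have been measured in a functional assay on CHOK cells for antagonist activity at growth hormone secretagogue receptor type 1 (Homo sapiens), read by calcium flux; a higher number here means a weaker inhibitor, a lower number a stronger inhibitor. Compound 1 `CCc1nc(N)nc(N)c1-c1ccc(NCc2ccc(C(C)=O)cc2)cc1` gives 110 nM in this assay. Compound 2 `CCc1nc(N)nc(N)c1-c1ccc(NCc2cc(F)c(S(=O)(=O)C(F)(F)F)c(F)c2)cc1` gives 690 nM. Compound 3 `Nc1nc(N)c(-c2ccc(NCc3ccnc(Cl)c3)cc2)c(COCc2ccccc2)n1` gives 3.6 nM, the lowest of the three numbers; its gap to compound 1, the nearest of the other two, and its wider gap to compound 2 both lie beyond the usual scatter of repeated measurements, so compound 3 stands as the strongest inhibitor of the set.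

Compound 4 `Nc1nc(N)c(-c2ccc(NCc3ccncc3)cc2)c(COCc2ccccc2)n1` has not yet been measured. It differs from compound 3 in one place: hydrogen in place of chloro on an aromatic carbon. Within the data shown here, no pair of measured compounds shows this same change, so its effect on the numbers is not known from what has been measured so far. The step of a 2.2-fold higher number from compound 3 to compound 4 (0.35 log units; beyond the scatter) is expected to be a modest move toward a higher number, meaning somewhat weaker inhibition, though a result within the scatter would not be surprising. Compound 4 is therefore estimated to give 8 nM, with a likely range from 2.5 nM to 30 nM.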

Compound 4, half-maximal inhibitory concentration: 86 nM
Estimate against measurement, compound 4: 11-fold (1.03 log units) below, outside the stated range (above it).
By their numbers in this assay, from the lowest: compound 3; then compounds 4 and 1 (each within the scatter of the next); then compound 2.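

Replacing the chloro of the 2-chloropyridin-4-yl group with hydrogen gives a 24-fold higher number from compound 3 to compound 4 (1.38 log units; beyond the scatter) in this assay, so the chloro on this aromatic carbon, next to the ring nitrogen, accounts for much of the strength of compound 3. Among these compounds, this is the first change in the set made in a single place, and it shows that the numbers in this assay respond strongly to what sits at this position. Nothing available explains why the chloro has so large an effect.

The compounds shown compare only chloro and hydrogen here, leaving open how a fluoro, a methyl or a methoxy group at this position would read. Among the compounds shown here, the change is also seen only with the side chain of compound 3, so its size with other side chains on the shared core remains open.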